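Tetrazole to carboxymethylamino on a quinoline ketone scaffold

The source may report more compounds than this note shows. Statements on the series, on what has been measured and on what is new or still open speak of the compounds shown alone.

The study covers four compounds tested in an assay for inhibition of 17-beta-hydroxysteroid dehydrogenase type 1 (Homo sapiens), read by HPLC, with a stated time of 10 min, tested at 1 uM; on this read-out lower numbers stand for less inhibition and higher numbers for more inhibition at the one concentration tested (going by the name of the read-out). Compound 1 `Cc1cc(-c2ccc3ccc(C(=O)c4ccc(F)c(O)c4)nc3c2)ccc1O` gives 11% in this assay. Compound 3 `CN(c1ccc(F)c(O)c1)c1cccc(-c2cccc(O)c2F)n1`, built on a different core, gives 99% in this assay. Compound 2 `O=C(c1ccc(F)c(O)c1)c1ccc2ccc(-c3nnn[nH]3)cc2n1` shares its ketone-bearing core with compound 1; in this assay compound 2 is reported only as "not active" (no number reported), so no single number stands for it; all that can be said is that it sits at the low end, with compound 1 also low and compound 3 high.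

Compound 4 `O=C(O)CNc1ccc2ccc(C(=O)c3ccc(F)c(O)c3)nc2c1` differs from compound 2 by the change ((carboxymethyl)amino in place of 1H-tetrazol-5-yl on an aromatic carbon), that is, a (carboxymethyl)amino group in place of a 1H-tetrazol-5-yl group on an aromatic carbon of the six-membered carbon ring that is meta to a fused ring and para to a fused ring. Going by the values given here, no step between two measured compounds has been recorded for this kind of change, so no directly comparable size of step is available. The account cannot point to a measured step and gives the expectation for compound 4 alone.

Given that compound 2 shows "not active" (no number reported) and compound 1 shows 11% on the same core, compound 4 is expected to show 10% in this assay, with a range from 0% to 35%.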

Compound 4, a percentage reported as inhibition, at one concentration (the size of the read-out at that concentration, not a potency): 3%
Beside the measured number, compound 4's estimate is 7 percentage points above it, within the range that was stated.
By their numbers in this assay, from the lowest: compounds 4 and 1 (each within the scatter of the next); then compound 3.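

In this assay compound 4 gives 3% and so puts a number on the shared core with a (carboxymethyl)amino group on this aromatic carbon, whereas compound 2, with its 1H-tetrazol-5-yl group, carries only the words "not active", and the step between those two cannot be read. Going by these compounds alone, the one step that can be read is a number a number 8 percentage points lower from compound 1 to compound 4 (within the scatter) and shows that (carboxymethyl)amino and 4-hydroxy-3-methylphenyl do not separate at this position, both staying low at the one concentration tested. No measurement at hand gives a cause for this result.

The compounds shown leave open whether a plain amine, a carboxylic acid set directly on the ring, or a longer chain ending in a carboxylic acid would read any differently at this position on the shared core. They also leave open how any of these groups would behave on the core of compound 3, which differs from the shared core in more than one place and so cannot be compared with it here.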